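Replacing methylamino with hydroxy on a weak growth inhibitor

The source may report more compounds than this note shows. Statements on the series, on what has been measured and on what is new or still open speak of the compounds shown alone.

Three related compounds set the scene here. In a functional assay on A549 cells (Homo sapiens) for inhibition, read by sulforhodamine B assay, with a stated time of 72 h (a higher number here means a weaker inhibitor of growth, a lower number a stronger inhibitor of growth), compound 1 (`CN1CCN(C(=O)/C=C/c2ccncc2-c2ccc3ccccc3c2)CC1`) gives > 10000 nM as its reading, a limit of the assay and not a number. Compound 3 (`O=C(CCc1ccncc1-c1ccc2ccccc2c1)N1CCOCC1`) gives > 10000 nM as its reading, again only a limit. Going by the values given here, compound 2 (`CNC(=O)/C=C/c1ccncc1-c1ccc2cc[nH]c2c1`) gives 7840 nM as the only actual number among the three. The picture is thin, resting largely on the limit of > 10000 nM in this assay, at which 2 of the 3 values shown sit, and on that single number.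

Compound 4 (`O=C(O)/C=C/c1ccncc1-c1ccc2cc[nH]c2c1`) keeps the core of compound 2 and carries hydroxy in place of methylamino on a carbonyl carbon, a difference that also reads as methylcarbamoyl to carboxy. Among the compounds with values here, no measured pair here shows this change, so the size of the step in this assay has to be judged without a direct guide. A modest move toward weaker growth inhibition is expected, because compound 2 at 7840 nM is the only one of the three to give a number at all. A reading reported only as a limit would be no surprise for compound 4. The expected change is a 1.5-fold higher number from compound 2 to compound 4 (0.18 log units; within the scatter) in this estimate. For compound 4 the estimated growth-inhibition concentration is 12000 nM with a likely range of 5000 nM to 30000 nM as its bounds.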

Compound 4, concentration for 50% growth inhibition: > 10000 nM
Compound 4 was reported as a limit (the forecaster's own chance of this, stated with the estimate: 60%); the middle value does not contradict the limit.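

In this assay compound 4 gives > 10000 nM, which is a limit of the assay and not a number. Hydroxy in place of methylamino on a carbonyl carbon gives an at least 1.2-fold higher number from compound 2 to compound 4 (0.10 log units; that floor lies within the scatter), the first step that can be read at this place, but it is only a floor, so the true size of the change could be close to nothing or far larger. What this adds is that methylcarbamoyl to carboxy does not produce a readable number on this core, leaving compound 2 as the only compound in the set with an actual value, and the set now rests even more heavily on one reading: the limit of > 10000 nM in this assay, at which 3 of the 4 values shown sit.

As far as these compounds go, how far compound 4 lies past that limit stays open, and so does whether this change truly weakens growth inhibition at all. Also open, from the compounds shown here alone, is whether another group on the same carbonyl carbon, such as a methoxy group to make the methyl ester or a plain amino group to make the primary amide, would give a real number and so allow a firm comparison with compound 2.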